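This account rests on a few compounds, and the source may have more. Where it says the series, first, only, none or still open, it means among the compounds named here.

Three compounds have so far been measured in a functional assay on HeLa cells (Homo sapiens) for cytotoxicity, read by resazurin assay, with a stated time of 72 h (on this read-out lower numbers stand for stronger inhibition and higher numbers for weaker inhibition), as follows:

- compound 1 (`COCCSC(=S)SCC(=O)c1ccc(OC)cc1`) gives 7880 nM
- compound 2 (`CCSC(=S)SCC(=O)c1ccc(C(=O)Nc2ccccc2)cc1`) gives 25800 nM
- compound 3 (`CCSC(=S)SCC(=O)c1ccc(C(=O)NCc2ccccc2)s1`) gives 13000 nM

Compound 2 (25800 nM) sits at the upper end of this small set, level within the scatter with compound 3 (13000 nM), while compound 1 (7880 nM) shows a lower number, beyond the scatter.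

Compound 4 (`CCSC(=S)SCC(=O)c1ccc(C(=O)NCCOc2ccccc2)cc1`) has not yet been measured. The change from compound 2 to compound 4 is 2-phenoxyethyl in place of phenyl on an amide-type nitrogen. Among the compounds with values here, no two measured compounds differ in one place only, so the size of this change has no direct measure. Since compound 2 (25800 nM) stands at the upper end of a narrow set, a slightly lower number is expected in this assay, but no step beyond the scatter. The expected change is the estimated step (a 1.6-fold lower number from compound 2 to compound 4 (0.21 log units; within the scatter)). Compound 4 is estimated at 16000 nM with a lower end of 6000 nM and an upper end of 40000 nM as the expected range.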

Compound 4, half-maximal inhibitory concentration: 18200 nM
Compound 4: the middle estimate sits 1.1-fold (0.06 log units) below what was measured, and the stated range covers the measured number.
By their numbers in this assay, from the lowest: compounds 1, 3, 4 and 2 (each within the scatter of the next, the first and the last beyond it).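

In this assay, within the data shown here, placing 2-phenoxyethyl in place of phenyl on an amide-type nitrogen gives a 1.4-fold lower number from compound 2 to compound 4 (0.15 log units; within the scatter), the first change in this set that can be read at a single place. At this nitrogen, whose other neighbour is the carbonyl carbon, a group of 9 heavy atoms with 1 hydrogen-bond acceptor thus replaces one of 6 heavy atoms with none, and compound 2 and compound 4 remain level. No measurement shown here gives a reason for this result.

The compounds shown leave open whether an amine, a carboxylic acid or a longer chain on this nitrogen would give a step beyond the scatter. They also leave open whether 2-phenoxyethyl in place of phenyl would give a similar step on the core of compound 3.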